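Swapping a Bromophenyl onto the Amine Arm

A few compounds are considered here, and "the series" means these few. Any claim that something is new, unique, unknown or untested is made for them only; others in the source may bear on it.

Compound 1 `COc1cc(Oc2cccc(Nc3ccccc3)c2)cc(OC)c1CNCCNC(C)=O` carries an acetamidomethyl group on a saturated chain carbon bound to an amine nitrogen. Going by the values given here, in a functional assay on SW-620 cells (Homo sapiens) for inhibition, read by MTT assay, with a stated time of 72 h (a higher number here means a weaker inhibitor, a lower number a stronger inhibitor), compound 1 gives 11900 nM, the highest of the three numbers measured so far. Compound 2 `COc1cc(Oc2cccc(Nc3ccccc3)c2)cc(OC)c1CNCc1ccc(Cl)cc1` gives 6340 nM in this assay, and compound 3 `COc1cc(Oc2cccc(Nc3ccccc3)c2)cc(OC)c1CNCc1ccc(O)cc1` gives 7940 nM. Compound 4 `COc1cc(Oc2cccc(Nc3ccccc3)c2)cc(OC)c1CNCc1ccc(Br)cc1` has not yet been measured; its change from compound 1 is 4-bromophenyl in place of acetamidomethyl on a saturated chain carbon bound to an amine nitrogen. Among the compounds with values here, two measured steps bear directly on it: a 1.9-fold lower number from compound 1 to compound 2 (0.27 log units; within the scatter) and a 1.5-fold lower number from compound 1 to compound 3 (0.18 log units; within the scatter). Each trades the same acetamidomethyl group for an aromatic ring, and both stay within the scatter; the step of a 1.3-fold higher number from compound 2 to compound 3 (0.10 log units; within the scatter) between the two ring-bearing compounds is also within the scatter. Because a 1.9-fold lower number from compound 1 to compound 2 (0.27 log units; within the scatter) stayed within the scatter, compound 4 is expected to show a step of a 2.0-fold lower number from compound 1 to compound 4 (0.30 log units; within the scatter), not beyond the scatter, in this assay. Compound 4 is therefore estimated at 6000 nM, within a range from 3000 nM to 12000 nM.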

Compound 4, half-maximal inhibitory concentration: 11200 nM
Beside the measured number, compound 4's estimate is 1.9-fold (0.27 log units) below it; the range from low to high includes it.
By their numbers in this assay, from the lowest: compounds 2, 3, 4 and 1 (each within the scatter of the next).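

In this assay, the measured step is a 1.1-fold lower number from compound 1 to compound 4 (0.03 log units; within the scatter), so 4-bromophenyl joins 4-chlorophenyl and 4-hydroxyphenyl as replacements for acetamidomethyl on a saturated chain carbon bound to an amine nitrogen, and none of the three steps leaves the scatter. Changing only the group on the aromatic carbon also leaves the numbers indistinguishable, with a 1.8-fold higher number from compound 2 to compound 4 (0.25 log units; within the scatter) and a 1.4-fold higher number from compound 3 to compound 4 (0.15 log units; within the scatter), so chloro, hydroxy and bromo cannot be told apart here. Across these four compounds, neither the acetamidomethyl-to-ring swap nor the choice among these three ring groups gives a step beyond the scatter. Still open, as far as these compounds go, is whether a carboxylic acid or a longer chain on this arm would give a step beyond the scatter. Nothing measured here offers an explanation for these numbers.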